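The source may report more compounds than this note shows. Statements on the series, on what has been measured and on what is new or still open speak of the compounds shown alone.

Compound 3, drawn as `CNC(=O)c1c(NO)cc(-c2ccc(F)cc2)oc1=O`, carries a methyl on its amide-type nitrogen and a fluoro on its pendant aromatic ring. In an ADME assay on Huh-7 cells (Homo sapiens) for cytotoxicity, read by a luciferase reporter and WST assay, with a stated time of 3 days (on this read-out lower numbers stand for higher toxicity in this test and higher numbers for lower toxicity in this test), compound 3 gives > 20000 nM, which is a limit of the assay and not a measured number. Compound 1, drawn as `Cc1ccc(NC(=O)c2c(NO)cc(-c3ccc(F)cc3)oc2=O)cc1`, gives > 20000 nM in this assay, again a limit. Compound 2, drawn as `COc1ccc(-c2cc(NO)c(C(=O)Nc3ccc(C)cc3)c(=O)o2)cc1`, gives > 20000 nM in this assay, also a limit. All three values thus sit at the same limit, as summed up by the limit of > 20000 nM in this assay, at which 3 of the 3 values shown sit.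

Compound 4, drawn as `CNC(=O)c1c(NO)cc(-c2ccc(OC)cc2)oc1=O`, differs from compound 3 by a single change: methoxy in place of fluoro on an aromatic carbon. The same swap has been made once before, in the step from compound 1 to compound 2, which is a step that the two limits leave unreadable from compound 1 to compound 2, and the change of the amide substituent from compound 1 to compound 3 is a step that the two limits leave unreadable from compound 1 to compound 3. Neither step yields a readable size, because both ends of each sit at the limit recorded in the limit of > 20000 nM in this assay, at which 3 of the 3 values shown sit. Within the data shown here, no measured step therefore points to any direction for compound 4, and the expectation is that it too will sit at the limit.

The estimated step from compound 3 to compound 4 is a step that the limit leaves unreadable from compound 3 to compound 4, meaning no change beyond the scatter is expected. Compound 4 is accordingly expected to give about 30000 nM in this assay, within a range from 15000 nM to 80000 nM.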

Compound 4, half-maximal cytotoxic concentration: > 20000 nM
Compound 4: only a limit was reported; the forecaster's own chance of this, stated with the estimate: 85%; the middle value does not contradict the limit.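

The steps to compound 4 from compound 3 and from compound 2 cannot be read, as both ends of each sit at the same limit of this assay: the limit of > 20000 nM in this assay, at which 4 of the 4 values shown sit. The compounds shown leave open how toxic any of them would be at higher concentrations, and whether methoxy in place of fluoro changes that at all.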